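This account rests on a few compounds, and the source may have more. Where it says the series, first, only, none or still open, it means among the compounds named here.

Measured so far:
Compound 1 `COc1cc2c(cc1OC)C(CC(=O)NC(C)(C)C)CC2`: 40%
Compound 2 `COc1cc2c(cc1OC)C(CC(=O)NCc1ccccc1)CC2`: 43.3%

Both compounds share one core and differ only in the group carried on the amide nitrogen. In a functional assay on the whole organism (strain Wistar) for inhibition, with Rattus norvegicus as the target, read by paw edema, with stated times of 60 min and 24 h, at a dose of 100 mg/kg by the oral route (a higher number here means more inhibition at the dose given (going by the name of the read-out), a lower number less inhibition), compound 1 gives 40%, the smaller of the two numbers shown, while compound 2 gives 43.3%; the gap between them is within the scatter, so the two cannot be told apart.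

Compound 3 `COc1cc2c(cc1OC)C(CC(=O)N1CCCCC1)CC2` has not yet been measured in this assay. It differs from compound 1 in one place: piperidin-1-yl in place of (tert-butyl)amino on a carbonyl carbon. The nitrogen is thereby drawn into a six-membered non-aromatic ring and the amide hydrogen is gone.

Going by the values given here, only one measured step bears on this, and loosely: exchanging the group on the amide nitrogen gave a number 3.3 percentage points higher from compound 1 to compound 2 (within the scatter), within the scatter. That step kept the amide hydrogen, whereas the step to compound 3 removes it, so the data do not speak directly to the new change. With nothing beyond the scatter seen so far, the step to compound 3 is expected to be about no change at the digits printed from compound 1 to compound 3 (within the scatter). Compound 3 is therefore estimated at 40%, with a range from 25% to 55%.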

Compound 3, a percentage reported as inhibition, in the whole organism at one dose (the size of the read-out at that dose, not a potency): 40%
Compound 3: middle estimate and measured number agree at the digits printed, and the stated range covers the measured number.
By their numbers in this assay, from the lowest: compounds 1, 3 and 2 (each within the scatter of the next).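

In this assay, replacing (tert-butyl)amino with piperidin-1-yl on the carbonyl carbon gives no change at the digits printed from compound 1 to compound 3 (within the scatter) and replacing benzylamino with the same group gives a number 3.3 percentage points lower from compound 2 to compound 3 (within the scatter) in the second comparison. Going by these compounds alone, compound 1 and compound 2 both keep the amide hydrogen, so this is the first sign that a compound without it, with the nitrogen drawn into a six-membered non-aromatic ring, reads within the scatter of compounds that have it, at least at this single oral dose. Nothing among these results accounts for the level read-out across the three groups, and the data offer no measured property of them to draw on.

The compounds shown leave open whether a different kind of group on the carbonyl carbon would move the number beyond the scatter, such as a morpholin-4-yl ring, a plain amino group or a hydroxyl group that would make the carboxylic acid. They also leave open what happens with a longer chain between the carbonyl and the shared core, or with other groups in place of the two methoxy groups on it.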